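Working notes: compound 3 to compound 4 in the series

The source may hold more compounds than are shown below. What is called first, only, known or untested is meant among the compounds shown, and "the series" means these compounds.

Among the measured compounds shown here, compound 3 `CC(C)(C)Cc1cnc(CCc2ccc(-c3ccccc3C(=O)O)cc2)[nH]1` gives 106 nM in an in vitro functional assay on cells for agonist activity at Bombesin receptor subtype-3 (Homo sapiens), read by luminescence and calcium flux (on this read-out lower numbers stand for an effect already at smaller amounts and higher numbers for an effect only at larger amounts of compound), and stands second highest of the three numbers measured so far. Its nearest neighbour is compound 2 `CC(C)(C)CCc1cnc(CCc2ccc(-c3ccccc3C(=O)O)cc2)[nH]1` with 39 nM, the step being a 2.7-fold higher number from compound 2 to compound 3 (0.43 log units; beyond the scatter). Furthest away is compound 1 `O=C(O)c1ccccc1-c1ccc(CCc2ncc(-c3ccccc3)[nH]2)cc1` with 4950 nM; the steps from it are a 47-fold lower number from compound 1 to compound 3 (1.67 log units; beyond the scatter) and a 130-fold lower number from compound 1 to compound 2 (2.10 log units; beyond the scatter).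

Compound 4 `N#Cc1ccc(Cc2cnc(CCc3ccc(-c4ccccc4C(=O)O)cc3)[nH]2)cc1` is not yet measured. It differs from compound 3 by 4-cyanophenyl in place of tert-butyl on a saturated chain carbon bound to an aromatic carbon.

For the measured compounds named here, the steps that bear on this change are those from compound 1: a phenyl directly on the aromatic carbon gave much higher numbers than either saturated chain, and compound 4 brings an aromatic ring back, although one bond further out and carrying a nitrile. Going by the values given here, no measured pair shows a benzyl group in this place, so the size of the step is uncertain. A move back toward the number of compound 1 is expected, but not all the way, since compound 1 has no chain carbon between the ring and the aromatic carbon.

For compound 4 the expected step is a 6.6-fold higher number from compound 3 to compound 4 (0.82 log units; beyond the scatter). Compound 4 is therefore estimated at 700 nM, with a range from 120 nM to 4000 nM.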

Compound 4, half-maximal effective concentration: 5890 nM
Beside the measured number, compound 4's estimate is 8.4-fold (0.93 log units) below it; the measured number lies above the stated range.
By their numbers in this assay, from the lowest: compound 2; then compound 3; then compounds 1 and 4 (each within the scatter of the next).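

In this assay, an aromatic ring on the saturated chain carbon does not keep the low numbers of the purely saturated groups: the change to 4-cyanophenyl gives a 56-fold higher number from compound 3 to compound 4 (1.74 log units; beyond the scatter), and the same comparison with the longer chain gives a 150-fold higher number from compound 2 to compound 4 (2.18 log units; beyond the scatter). The earlier compounds shown here suggested that moving the ring one bond further out might recover part of the gap, but replacing phenyl on the aromatic carbon with 4-cyanobenzyl gives a 1.2-fold higher number from compound 1 to compound 4 (0.08 log units; within the scatter), so the added chain carbon together with the nitrile brings no change beyond the scatter. Across the four compounds shown, both with an aromatic ring in this region sit well above both with a saturated chain, with no exception, but nothing available explains this difference.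

The compounds shown leave open whether the step belongs to the aromatic ring itself or to the nitrile it carries, a question that an unsubstituted benzyl group in this place would address. They also leave open whether a saturated ring, such as cyclohexylmethyl, would follow the low numbers of the open chains or the high numbers of the aromatic groups.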